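Swapping an aryl for a benzyl on a triazine anilino nitrogen

A few compounds are considered here, and "the series" means these few. Any claim that something is new, unique, unknown or untested is made for them only; others in the source may bear on it.

Compound 1 `COc1ccc(Nc2nc(Cl)nc(Nc3ccc(-c4nc5ccccc5o4)cc3)n2)cc1` gives 270000 nM in a functional assay on MCF7 cells (Homo sapiens) for cytotoxicity, read by MTT assay, with a stated time of 24 h; on this read-out higher numbers stand for weaker inhibition and lower numbers for stronger inhibition.
Compound 2 `Fc1ccc(Nc2nc(Cl)nc(Nc3ccc(-c4nc5ccccc5o4)cc3)n2)cc1` gives 68400 nM in this assay.
Compound 3 `Clc1nc(NCc2ccccc2)nc(Nc2ccc(-c3nc4ccccc4o3)cc2)n1` is not yet measured.

Compound 2 has the lowest of the two numbers shown; the only step measured, a 3.9-fold lower number from compound 1 to compound 2 (0.60 log units; beyond the scatter), was modest. Compound 3 differs from compound 2 by benzyl in place of 4-fluorophenyl on a nitrogen on an aromatic ring. Going by the values given here, no measured step touches this nitrogen substituent in the same way, so the single step gives only a rough sense that changes here shift the number modestly. An outcome close to compound 2, within a broad range, is therefore expected, a 1.1-fold lower number from compound 2 to compound 3 (0.06 log units; within the scatter). Compound 3 is estimated at 60000 nM, with a range from 15000 nM to 250000 nM.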

Compound 3, half-maximal inhibitory concentration: 66100 nM
The estimate for compound 3 lay 1.1-fold (0.04 log units) below the measured number, within the range that was stated.
By their numbers in this assay, from the lowest: compounds 3 and 2 (each within the scatter of the next); then compound 1.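

In this assay, the ring on this nitrogen need not be attached directly: benzyl in place of 4-fluorophenyl gives a 1.0-fold lower number from compound 2 to compound 3 (0.01 log units; within the scatter), so compound 2 and compound 3 cannot be told apart. Benzyl in place of 4-methoxyphenyl gives a 4.1-fold lower number from compound 1 to compound 3 (0.61 log units; beyond the scatter), which leaves compound 1 apart from the other two. No measurement here offers an explanation for either result.

As far as these compounds go, whether a longer chain such as phenethyl on this nitrogen, or a methoxy group on the benzyl ring, would shift the number remains open.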